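Adding a Methoxy Group to Compound 3

A few compounds are considered here, and "the series" means these few. Any claim that something is new, unique, unknown or untested is made for them only; others in the source may bear on it.

Of the compounds shown here, three have been measured in a functional assay on MOLT-4 cells (Homo sapiens) for antiproliferative activity, with a stated time of 48 h; on this read-out lower numbers stand for stronger inhibition and higher numbers for weaker inhibition. Compound 1 `C=C(Br)C(=O)Nc1ccc(C(=O)/C=C/c2ccccc2)cc1` gives 500 nM. Compound 2 `C=C(Br)C(=O)Nc1ccc(C(=O)/C=C/c2ccc(OC)cc2)cc1` gives 610 nM; the change between them is methoxy in place of hydrogen on an aromatic carbon, and it produced a 1.2-fold higher number from compound 1 to compound 2 (0.09 log units; within the scatter). Compound 3 `Nc1ccc(C(=O)/C=C/c2ccccc2)cc1` gives 7900 nM, the highest number of the three. The cores of compound 1 and compound 3 differ by hydrogen in place of (1-bromoethenyl)carbonyl on a nitrogen on an aromatic ring, and this change produced a 16-fold higher number from compound 1 to compound 3 (1.20 log units; beyond the scatter).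

Compound 4 `COc1cccc(/C=C/C(=O)c2ccc(N)cc2)c1` has not yet been measured. It differs from compound 3 by methoxy in place of hydrogen on an aromatic carbon. This is the same kind of change as that between compound 1 and compound 2, but not identical in place: in compound 2 the methoxy sits para to a large group, whereas in compound 4 it sits meta to a large group. Because the earlier change gave a 1.2-fold higher number from compound 1 to compound 2 (0.09 log units; within the scatter), the expected step here is a 1.1-fold higher number from compound 3 to compound 4 (0.03 log units; within the scatter), with the difference in place adding some uncertainty. Compound 4 is therefore estimated at 8500 nM in this assay. Its number is expected to fall between 4000 nM and 18000 nM.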

Compound 4, half-maximal inhibitory concentration: 21000 nM
Beside the measured number, compound 4's estimate is 2.5-fold (0.39 log units) below it; measured number outside the range, above it.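

In this assay, methoxy in place of hydrogen on an aromatic carbon gave a 2.7-fold higher number from compound 3 to compound 4 (0.42 log units; beyond the scatter). Taken alone, this step is beyond the scatter, but set beside the earlier one it does not show that the change behaves differently on the two cores: the same change on two cores in this assay, a 1.2-fold higher number (0.09 log units; within the scatter) from compound 1 to compound 2 and a 2.7-fold higher number (0.42 log units; beyond the scatter) from compound 3 to compound 4, 2.2-fold (0.34 log units) apart, within the scatter of two such steps. This shows only that the two results are compatible with a similar effect; it does not prove that the effect carries over from core to core, as there are just two pairs, and the methoxy sits meta to a large group in compound 4 but in a different place in compound 2.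

Still open, going by these compounds, is whether the core or the place of the methoxy matters more, since compound 2 and compound 4 differ in both. Also open, on these data alone, is how a hydroxyl group, an amine or a longer chain such as ethoxy would compare with methoxy on either core.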